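This account rests on a few compounds, and the source may have more. Where it says the series, first, only, none or still open, it means among the compounds named here.

Three compounds share one core and were tested in a functional assay on MKN-74 cells (Homo sapiens) for antiproliferative activity, with a stated time of 24 h; a higher number here means a weaker inhibitor, a lower number a stronger inhibitor. Compound 1 `NC(=O)c1c(NC(=O)c2ccccc2Cl)sc2c1CCN(Cc1ccccc1)C2` gives 14500 nM there. Compound 2 `N#Cc1ccccc1CN1CCc2c(sc(NC(=O)c3ccccc3Cl)c2C(N)=O)C1` gives 9500 nM in this assay, and compound 3 `NC(=O)c1c(NC(=O)c2ccccc2Cl)sc2c1CCN(Cc1ccc(Cl)cc1)C2` gives 18700 nM. Compound 2 holds the lowest number of the three, yet a 1.5-fold lower number from compound 1 to compound 2 (0.18 log units; within the scatter) and a 2.0-fold higher number from compound 2 to compound 3 (0.29 log units; within the scatter) both stay within the scatter, as does a 1.3-fold higher number from compound 1 to compound 3 (0.11 log units; within the scatter), so the three compounds are not truly told apart.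

Compound 4 `NC(=O)c1c(NC(=O)c2ccccc2Cl)sc2c1CCN(Cc1ccc([N+](=O)[O-])cc1)C2` has not been measured. It differs from compound 2 by 4-nitrophenyl in place of 2-cyanophenyl on a saturated chain carbon bound to an amine nitrogen in a ring. The step that bears most closely on this change is a 2.0-fold higher number from compound 2 to compound 3 (0.29 log units; within the scatter), another exchange of the group at that place, together with a 1.3-fold higher number from compound 1 to compound 3 (0.11 log units; within the scatter). Since neither moved beyond the scatter, no step beyond the scatter is expected in this assay, and the expected step is a 1.4-fold higher number from compound 2 to compound 4 (0.14 log units; within the scatter). Compound 4 is therefore estimated at 13000 nM, with a likely range from 5500 nM to 32000 nM.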

Compound 4, half-maximal inhibitory concentration: 31500 nM
Beside the measured number, compound 4's estimate is 2.4-fold (0.38 log units) below it, within the range that was stated.
By their numbers in this assay, from the lowest: compounds 2, 1, 3 and 4 (each within the scatter of the next, the first and the last beyond it).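

In this assay, the group on the saturated chain carbon can move the number beyond the scatter: 4-nitrophenyl gives a 2.2-fold higher number from compound 1 to compound 4 (0.34 log units; beyond the scatter) and a 3.3-fold higher number from compound 2 to compound 4 (0.52 log units; beyond the scatter). Nitro in place of chloro gives a 1.7-fold higher number from compound 3 to compound 4 (0.23 log units; within the scatter), which stays within the scatter, so compound 4 is not told apart from compound 3. The shift is modest and points towards a weaker inhibitor in both steps beyond the scatter.

Nothing available explains why these steps have this size. On these data alone, whether an amine or a carboxylic acid on the aromatic ring would give a lower or higher number remains open.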